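Hydroxy to methoxy on compound 1

The source may report more compounds than this note shows. Statements on the series, on what has been measured and on what is new or still open speak of the compounds shown alone.

Measured so far in a functional assay on ASPC1 cells (Homo sapiens) for antiproliferative activity, read by sulforhodamine B assay, with a stated time of 48 h; a higher number here means a weaker inhibitor, a lower number a stronger inhibitor:
- compound 1 `O=C(CCCCCCN1C(=O)/C(=N\O)c2cc([N+](=O)[O-])ccc21)NO`: 4680 nM
- compound 2 `Cc1ccc2c(c1)/C(=N/O)C(=O)N2CCCCCCC(=O)NO`: 2440 nM

Compound 1 and compound 2, the only two measured, lie within the scatter of each other, so neither ranks ahead. Compound 3 `CO/N=C1\C(=O)N(CCCCCCC(=O)NO)c2ccc([N+](=O)[O-])cc21` keeps the core of compound 1 with one change: methyl in place of hydrogen on an oxygen. Among the measured compounds shown here, the sole measured step, a 1.9-fold lower number from compound 1 to compound 2 (0.28 log units; within the scatter), is methyl in place of nitro on an aromatic carbon, a different change that says little about this one. No step beyond the scatter is therefore expected in this assay, though with little evidence. The expected step is a 1.2-fold lower number from compound 1 to compound 3 (0.07 log units; within the scatter). Compound 3 is estimated at 4000 nM, with an expected range of 1500 nM to 11000 nM.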

Compound 3, half-maximal inhibitory concentration: 840 nM
Compound 3: middle estimate off by 4.8-fold (0.68 log units), on the high side; measured number below the stated range.
By their numbers in this assay, from the lowest: compound 3; then compounds 2 and 1 (each within the scatter of the next).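

In this assay, among the compounds shown here, the change from hydroxy to methoxy gives a 5.6-fold lower number from compound 1 to compound 3 (0.75 log units; beyond the scatter) and is the first step in this small set that lies beyond the scatter. A single methyl on this oxygen, whose other neighbour is a double-bonded nitrogen, therefore moves the number more than the swap of nitro for methyl did. No evidence here accounts for this gain. Still open, on these data alone, is whether ethyl or benzyl on the same oxygen would lower the number further. This one pair also cannot show whether methoxy would give a similar step on the core of compound 2.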